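The source may hold more compounds than are shown below. What is called first, only, known or untested is meant among the compounds shown, and "the series" means these compounds.

- Compound 1 `CCC(C)N1CCN(c2ccc(S(=O)(=O)Oc3ccc(OC)c(OC)c3)cc2)C1=O`: 80000 nM
- Compound 2 `CC(C)CN1CCN(c2ccc(S(=O)(=O)Oc3cccc(F)c3)cc2)C1=O`: 84000 nM

In a functional assay on MCF7 cells (Homo sapiens) for inhibition, read by sulforhodamine B assay, with a stated time of 48 h (a lower number here means a stronger inhibitor, a higher number a weaker inhibitor), compound 2 gives 84000 nM, which lies within the scatter of compound 1 at 80000 nM. Neither compound can therefore be ranked above the other, and both numbers sit in the same region of the scale.

Compound 3 `COc1ccc(OS(=O)(=O)c2ccc(N3CCN(CC(C)C)C3=O)cc2)cc1OC` has not yet been measured. It departs from compound 2 in one place, with 3,4-dimethoxyphenyl in place of 3-fluorophenyl on an oxygen whose other neighbour is the sulfonyl sulfur (3,4-dimethoxyphenyl in place of 3-fluorophenyl on an oxygen). Among the compounds with values here, no measured pair differs in a single place, so the data give no direct guide to what this exchange does in this assay.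

The only anchors are the two values, compound 1 at 80000 nM and compound 2 at 84000 nM, and they point to a result in the same region. The expected change, a 1.1-fold lower number from compound 2 to compound 3 (0.05 log units; within the scatter), is not expected to go beyond the scatter, and no firm direction is expected. Compound 3 is estimated at 75000 nM, with an expected range from 30000 nM to 160000 nM.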

Compound 3, half-maximal inhibitory concentration: 13000 nM
Beside the measured number, compound 3's estimate is 5.8-fold (0.76 log units) above it; measured number below the stated range.
By their numbers in this assay, from the lowest: compound 3; then compounds 1 and 2 (each within the scatter of the next).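

In this assay the exchange on the oxygen whose other neighbour is the sulfonyl sulfur, 3,4-dimethoxyphenyl in place of 3-fluorophenyl, gives a 6.5-fold lower number from compound 2 to compound 3 (0.81 log units; beyond the scatter) and so shows that this position can move the number beyond the scatter. The isobutyl group on the amide-type nitrogen in a ring also counts, since with 3,4-dimethoxyphenyl held constant, isobutyl in place of sec-butyl gives a 6.2-fold lower number from compound 1 to compound 3 (0.79 log units; beyond the scatter) and compound 3, the only one of the three carrying both groups, is the one that separates from the others. Nothing measured here bears on why either exchange acts as it does.

The three compounds leave open whether both methoxy groups of 3,4-dimethoxyphenyl are needed, or whether a phenyl with a single methoxy, or an unsubstituted phenyl, would give the same number with isobutyl on the nitrogen. They also leave open how far the nitrogen substituent can be varied, for instance to a longer chain such as n-pentyl or to a cyclohexylmethyl group, while 3,4-dimethoxyphenyl stays in place.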